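Tolerated concentration after swapping the carbamoyl side chain

The source may report more compounds than this note shows. Statements on the series, on what has been measured and on what is new or still open speak of the compounds shown alone.

Measured in an ADME assay on HOS cells (Homo sapiens) for cytotoxicity; a lower number here means that less compound is tolerated, a higher number that more compound is tolerated:
- Compound 1 `CN(Cc1nc2ccccc2n1CCCCCN)C1CCCc2cccnc21`: 4500 nM
- Compound 2 `CN(Cc1nc2cccc(C(=O)NCCCCN)c2[nH]1)C1CCCc2cccnc21`: > 20000 nM, a limit and not a number

Compound 2 has no exact value in this assay. Its reading is the limit of > 20000 nM in this assay, at which 1 of the 2 values shown sits.

Compound 3 `CN(C)CCCc1cccc2nc(CN(C)C3CCCc4cccnc43)[nH]c12` shares the core of compound 2 but carries 3-(dimethylamino)propyl in place of (4-aminobutyl)carbamoyl on an aromatic carbon. Among the compounds with values here, no measured pair isolates this change, so the expectation rests on little. Compound 1, which also lacks the carbamoyl, gives 4500 nM, and this points to a modest move towards less compound being tolerated. The expected change is an at least 1.5-fold lower number from compound 2 to compound 3 (0.18 log units; that floor lies within the scatter), a moderate downward step, although a reading at the limit remains possible. For compound 3 the estimated value is 13000 nM, with an expected range from 5000 nM to 30000 nM.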

Compound 3, half-maximal cytotoxic concentration: 7500 nM
The estimate for compound 3 lay 1.7-fold (0.24 log units) above the measured number; the range from low to high includes it.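

At this aromatic carbon of the shared core, the side chain decides whether a reading falls within the measured range of this assay. With 3-(dimethylamino)propyl in place of (4-aminobutyl)carbamoyl, the data show an at least 2.6-fold lower number from compound 2 to compound 3 (0.42 log units; beyond the scatter), so the carbamoyl chain is not interchangeable with this basic-looking name-for-name swap at this position. Going by these compounds, the true size of the step stays unknown because compound 2 reads only as a limit and not as a number: the limit of > 20000 nM in this assay, at which 1 of the 3 values shown sits.

The swap removes the carbamoyl and changes the chain end in one step, so the compounds shown do not tell which of the two goes with the lower number. A 3-aminopropyl chain or a longer chain ending in dimethylamino on the same aromatic carbon remains an open case.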